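Replacing a cyclohexane acid with a fluorinated sulfone ring

The source may report more compounds than this note shows. Statements on the series, on what has been measured and on what is new or still open speak of the compounds shown alone.

Compound 1, `CC[C@]1(C(=O)O)CC[C@H](C(=O)N2CC[C@](c3ccc(C(F)(C(F)(F)F)C(F)(F)F)cc3)(S(=O)(=O)c3ccc(F)cc3)C2)CC1`, carries a 4-carboxy-4-ethylcyclohexyl group on a carbonyl carbon attached to a ring nitrogen. In an ADME assay on microsomes from liver (Mus musculus) for metabolic stability, with a stated time of 10 min (a higher number here means that more of the compound is left, a lower number that less of the compound is left), compound 1 stands at "not determined" (no result reported), so no number for it is known. Among the compounds with values here, the only measured relative is compound 2, `O=C(C1CCS(=O)(=O)C1)N1CC[C@](c2ccc(C(F)(C(F)(F)F)C(F)(F)F)cc2)(S(=O)(=O)c2ccc(F)cc2)C1`, which in this assay gives 78%; 96% (2 entries), two readings that lie within the usual scatter of each other (the several entries of compound 2 in this assay, 78%; 96% (2 entries)).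

Compound 3, `O=C(N1CC[C@](c2ccc(C(F)(C(F)(F)F)C(F)(F)F)cc2)(S(=O)(=O)c2ccc(F)cc2)C1)C1(F)CCS(=O)(=O)CC1`, is the target of the step. The change 4-fluoro-1,1-dioxothian-4-yl in place of 4-carboxy-4-ethylcyclohexyl on a carbonyl carbon puts a 4-fluoro-1,1-dioxothian-4-yl group where the 4-carboxy-4-ethylcyclohexyl group stood, on the carbonyl carbon whose other neighbour is the amide-type nitrogen in a ring. Within the data shown here, since compound 1 has no number, no size or direction can be set for the step from compound 1 to compound 3 in this assay; the only guide is compound 2, whose readings the several entries of compound 2 in this assay, 78%; 96% (2 entries) show a largely intact compound after the stated time.

On that basis compound 3 is expected to give about 80% in this assay, estimated to fall between 55% and 98%.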

Compound 3, percent of the compound remaining: 90%
Compound 3: middle estimate off by 10 percentage points, on the low side; low and high end bracket the measured number.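

In this assay compound 3 gives 90%, while compound 1 stands at "not determined" (no result reported), so the step between these two compounds cannot be read. The compounds shown leave open how far, and in which direction, putting the 4-fluoro-1,1-dioxothian-4-yl group in place of the 4-carboxy-4-ethylcyclohexyl group changes the amount of compound left.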